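The compounds below may be only part of what the source reports. "The series", "measured", "known", "first", "only" and "open" are said of these compounds alone.

The measured compounds, each with its result in an ADME assay on microsomes from liver (Canis lupus familiaris) for metabolic stability; on this read-out lower numbers stand for a shorter-lived compound and higher numbers for a longer-lived compound:
Compound 1 `Nc1nc(NCCNc2ncc(-c3ncc[nH]3)c(-c3ccccc3Cl)n2)ccc1[N+](=O)[O-]` gives > 0.5 h, which is a limit of the assay rather than a number.
Compound 2 `Nc1nc(NCCNc2ncc(-c3ncc[nH]3)c(-c3ccc(F)cc3Cl)n2)ccc1[N+](=O)[O-]` gives > 0.5 h, again a limit.
Compound 3 `Cc1cc(Cl)ccc1-c1nc(NCCNc2ccc([N+](=O)[O-])c(N)n2)ncc1-c1ncc[nH]1` gives > 0.5 h, again a limit.

Compound 1 therefore stands at the limit where all three measured values sit (the limit of > 0.5 h in this assay, at which 3 of the 3 values shown sit); no number places it apart from the other two. The compound still to be measured is compound 4 `COc1cc(Cl)ccc1-c1nc(NCCNc2ccc([N+](=O)[O-])c(N)n2)ncc1-c1ncc[nH]1`. It differs from compound 1 in one place: 4-chloro-2-methoxyphenyl in place of 2-chlorophenyl on an aromatic carbon. The measured steps that come closest exchange groups on the same ring: a step that the two limits leave unreadable from compound 1 to compound 3 and a step that the two limits leave unreadable from compound 2 to compound 3, with a step that the two limits leave unreadable from compound 1 to compound 2 as the third. All three run from one limit to another, so none offers a size that can be read. Going by the values given here, with every measured compound at the limit (the limit of > 0.5 h in this assay, at which 3 of the 3 values shown sit), the expectation is that compound 4 also reaches it in this assay, with no step readable in either direction; the estimated step is a step that the limit leaves unreadable from compound 1 to compound 4. Compound 4 is estimated at 1 h, between 0.5 h and 3 h, and most likely the assay will again report only a limit.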

Compound 4, half-life: > 0.5 h
Compound 4: no number, only a limit (the forecaster's own chance of this, stated with the estimate: 85%); the middle value does not contradict the limit.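

Going by these compounds alone, the result for compound 4 is again only a limit, and no step to it from compound 1, compound 2 or compound 3 can be read. All four compounds share the same limit: the limit of > 0.5 h in this assay, at which 4 of the 4 values shown sit.

The compounds shown leave open how long each one actually lasts in this assay, and whether methoxy in place of methyl makes any difference.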